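Cyano to Ethoxycarbonyl, Twice, Against a Shared Limit

The source may hold more compounds than are shown below. What is called first, only, known or untested is meant among the compounds shown, and "the series" means these compounds.

The measured compounds in a functional assay on Raji cells (Homo sapiens) for cytotoxicity, with a stated time of 72 h (a higher number here means that more compound is needed for the effect, a lower number that less compound is needed), are:
compound 1, `C=C[C@@](C)(/C=C/c1ccc(O)cc1)CC/C=C/C(=O)OCC`, with > 26000 nM
compound 2, `C=C[C@@](C)(/C=C/c1ccc(O)cc1)CC/C=C/C#N`, with > 26000 nM
compound 3, `COc1ccc(/C=C/[C@@](C)(/C=C/c2ccc(O)c(/C=C/C#N)c2)CCC=C(C)C)cc1`, with > 26000 nM

Each of these three values is a limit of this assay, not a number. The picture is summarised by the limit of > 26000 nM in this assay, at which 3 of the 3 values shown sit.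

Compound 2 and compound 1 differ in one place: ethoxycarbonyl in place of cyano on a double-bonded chain carbon bound to a double-bonded chain carbon. Because both end at a limit, the step that the two limits leave unreadable from compound 2 to compound 1 cannot be read in size or direction; the data allow no more than that.

How the core of compound 3 differs from the core of compound 2 is not broken down here; the two differ in more than one place.

The compound not yet measured is compound 4, `CCOC(=O)/C=C/c1cc(/C=C/[C@](C)(/C=C/c2ccc(OC)cc2)CCC=C(C)C)ccc1O`. It is related to compound 3 by the same change that relates compound 2 to compound 1, namely (ethoxycarbonyl in place of cyano on a double-bonded chain carbon bound to a double-bonded chain carbon). Since compound 3 sits at the limit, and since the same change left the pair of compound 2 and compound 1 both at the limit, compound 4 is expected to give 40000 nM, which is estimated to lie between 15000 nM and 120000 nM. The step this estimate means, a step that the limit leaves unreadable from compound 3 to compound 4, is expected to be as unreadable as the earlier one, with another limit the most likely outcome.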

Compound 4, half-maximal effective concentration: > 26000 nM
Compound 4: only a limit was reported; the forecaster's own chance of this, stated with the estimate: 85%; the middle value lies beyond the limit too.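

In this assay compound 4 gives > 26000 nM, which is a limit of the assay and not a number. Compound 3 also ends at a limit, so the change from cyano to ethoxycarbonyl between compound 3 and compound 4 yields no readable step. The picture is now this: the limit of > 26000 nM in this assay, at which 4 of the 4 values shown sit.

The compounds shown leave open how any of the four compares with another in this assay, and whether this change alters the read-out at all.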